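Notes on amide aryl replacements, compounds 1 to 4

The source may hold more compounds than are shown below. What is called first, only, known or untested is meant among the compounds shown, and "the series" means these compounds.

Compound 1 `CCn1cc(C(=O)Nc2ccccc2O)c(=O)c2cc(F)c(N3CCNC(C)C3)c(F)c21`: 7430 nM
Compound 2 `CCn1cc(C(=O)Nc2cccc([N+](=O)[O-])c2)c(=O)c2cc(F)c(N3CCNC(C)C3)c(F)c21`: 3250 nM
Compound 3 `CCn1cc(C(=O)Nc2ccc(C)c([N+](=O)[O-])c2)c(=O)c2cc(F)c(N3CCNC(C)C3)c(F)c21`: 4200 nM

All three have been measured in a functional assay on MDA-MB-231 cells (Homo sapiens) for cytotoxicity, read by MTT assay; on this read-out higher numbers stand for weaker inhibition and lower numbers for stronger inhibition. Compound 1 gives the highest of the three numbers; compound 3 is nearest, compound 2 furthest. Both steps away from compound 1 exchange the 2-hydroxyphenyl: a 2.3-fold lower number from compound 1 to compound 2 (0.36 log units; beyond the scatter), and a 1.8-fold lower number from compound 1 to compound 3 (0.25 log units; within the scatter). Within the nitro pair, a 1.3-fold higher number from compound 2 to compound 3 (0.11 log units; within the scatter).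

Compound 4 `CCn1cc(C(=O)Nc2ccc(C(C)=O)cc2)c(=O)c2cc(F)c(N3CCNC(C)C3)c(F)c21` is not yet measured. It differs from compound 1 as 4-acetylphenyl in place of 2-hydroxyphenyl on an amide-type nitrogen. Going by the values given here, the same 2-hydroxyphenyl leaves, but the acetyl group has no precedent in this set, so the two nitro steps are only a loose guide. A small lowering, or none beyond the scatter, is expected: a 1.7-fold lower number from compound 1 to compound 4 (0.22 log units; within the scatter). Compound 4 is therefore estimated at 4500 nM, in the range 2000 nM to 10000 nM.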

Compound 4, half-maximal inhibitory concentration: 5600 nM
Beside the measured number, compound 4's estimate is 1.2-fold (0.09 log units) below it; measured number inside the range.
By their numbers in this assay, from the lowest: compounds 2, 3, 4 and 1 (each within the scatter of the next, the first and the last beyond it).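

In this assay the 4-acetylphenyl amide lies within the scatter of every earlier compound (a 1.3-fold lower number from compound 1 to compound 4 (0.12 log units; within the scatter); a 1.3-fold higher number from compound 3 to compound 4 (0.12 log units; within the scatter); a 1.7-fold higher number from compound 2 to compound 4 (0.24 log units; within the scatter)). An aryl group carrying no nitro group therefore also stays within the scatter of compound 1, and the step from compound 1 to compound 2 remains the only one beyond it. Nothing available here accounts for these numbers. Open, as far as these compounds go, is how a phenyl ring carrying an amine or a carboxylic acid would read at this amide-type nitrogen. Also open is whether unsubstituted phenyl would differ from any of these compounds.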